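Swapping a fluoro for a methoxy on the benzylamine arm

The source may report more compounds than this note shows. Statements on the series, on what has been measured and on what is new or still open speak of the compounds shown alone.

Measured in a functional assay on ACHN cells (Homo sapiens) for inhibition, read by sulforhodamine B assay, with a stated time of 48 h; on this read-out higher numbers stand for weaker inhibition of growth and lower numbers for stronger inhibition of growth:
- compound 1 `Nc1cc(N)c2nc(-c3ccccc3)c(Oc3ccc(Cl)c(Cl)c3)nc2c1`: 9330 nM
- compound 2 `COc1ccc(CNc2nc3cc(N)cc(N)c3nc2-c2ccccc2)cc1OC`: 13800 nM
- compound 3 `Nc1cc(N)c2nc(-c3ccccc3)c(NCc3ccc(F)cc3)nc2c1`: 1700 nM

Compound 3 has the lowest number of the three, and both gaps to it lie beyond the scatter: a 5.5-fold lower number from compound 1 to compound 3 (0.74 log units; beyond the scatter) and an 8.1-fold lower number from compound 2 to compound 3 (0.91 log units; beyond the scatter). Within this small set it is therefore the strongest inhibitor of growth.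

Within the data shown here, compound 4 `COc1ccc(CNc2nc3cc(N)cc(N)c3nc2-c2ccccc2)cc1` keeps the shared core and the benzylamine arm of compound 3 and changes only one group: methoxy in place of fluoro on an aromatic carbon, sitting on an aromatic carbon of a six-membered aromatic ring of carbon only, para to a large group.

Among the measured compounds shown here, no measured pair shows exactly this swap. The closest guide is the step of an 8.1-fold lower number from compound 2 to compound 3 (0.91 log units; beyond the scatter), where a 3,4-dimethoxyphenyl gave way to a 4-fluorophenyl on the same chain carbon and the number fell by a modest margin. Compound 4 carries a single methoxy where compound 2 carried two, so the move back toward a methoxy-bearing ring is expected to cost some potency, though less than the full gap between compound 2 and compound 3.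

Compound 4 is thus expected to show a 2.6-fold higher number from compound 3 to compound 4 (0.42 log units; beyond the scatter), with an estimate of 4500 nM and a range from 1700 nM to 12000 nM in this assay.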

Compound 4, concentration for 50% growth inhibition: 14800 nM
The estimate for compound 4 lay 3.3-fold (0.52 log units) below the measured number, and the stated range ends below it.
By their numbers in this assay, from the lowest: compound 3; then compounds 1, 2 and 4 (each within the scatter of the next).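

In this assay, replacing fluoro with methoxy at this place, para to a large group, is a single change with a clear effect on growth inhibition (an 8.7-fold higher number from compound 3 to compound 4 (0.94 log units; beyond the scatter)). The earlier step from compound 2 to compound 3 could not show this, as it changed a 3,4-dimethoxyphenyl to a 4-fluorophenyl and so altered two ring positions at once. Compound 4 now separates those changes: hydrogen in place of the second methoxy leaves the number within the scatter (a 1.1-fold higher number from compound 2 to compound 4 (0.03 log units; within the scatter)), so among these compounds, the difference follows the fluoro-to-methoxy swap and the second methoxy adds no measurable change.

The compounds shown leave open how a hydrogen, a chlorine or a hydroxyl at this same place would compare, so they cannot tell whether fluoro strengthens growth inhibition, methoxy weakens it, or both. The data also offer no measured explanation for the gap between the 4-fluorobenzyl and 4-methoxybenzyl arms.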